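The compounds below may be only part of what the source reports. "The series", "measured", "known", "first", "only" and "open" are said of these compounds alone.

Measured so far:
compound 1, `CCc1nc(N)c2nc(O)n(Cc3ccccc3)c2n1`: 1 uM
compound 2, `Nc1ncnc2c1nc(Cl)n2Cc1ccccc1`: > 10 uM
compound 3, `COc1ccccc1Cn1c(O)nc2c(N)ncnc21`: 10 uM

In a functional assay (spleen, spleen) for activation, with Mus musculus as the target (a lower number here means that less compound is needed, a higher number that more compound is needed for the effect), compound 1 gives 1 uM and holds the lowest of the two numbers shown. Compound 3 gives 10 uM, a gap beyond the scatter. For compound 2 the result is only a limit of the assay, > 10 uM; that is what the limit of > 10 uM in this assay, at which 1 of the 3 values shown sits, records. Compound 4, `CCCSc1nc(N)c2nc(O)n(Cc3ccccc3)c2n1`, is not yet measured. It differs from compound 1 in one place: propylsulfanyl in place of ethyl on an aromatic carbon. For the measured compounds named here, no step between two measured compounds tracks this change, so no size is set by the data. In this assay the expectation for compound 4 is a modest move toward a lower number, if any. Compound 4 is expected to give 0.3 uM, with a range from 0.05 uM to 2 uM. The gap between compound 1 and compound 3 is the larger one. The expected step of a 3.3-fold lower number from compound 1 to compound 4 (0.52 log units; beyond the scatter) is small.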

Compound 4, minimum effective concentration: 0.01 uM
Estimate against measurement, compound 4: 30-fold (1.48 log units) above; measured number below the stated range.
By their numbers in this assay, from the lowest: compound 4; then compound 1; then compound 3.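

In this assay, for the compounds shown here, propylsulfanyl in place of ethyl brings a 100-fold lower number from compound 1 to compound 4 (2.00 log units; beyond the scatter) and this is the first size set for any change at this position, on an aromatic carbon between two ring nitrogen atoms. The change alters chain length and adds sulfur together, so this step cannot separate the two. Nothing measured here gives a reason for the size of this step.

Open, from the compounds shown here alone, is which of the two carries the step. A plain butyl chain, a propoxy group or an amine at this position would bear on that question.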